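The source may hold more compounds than are shown below. What is called first, only, known or untested is meant among the compounds shown, and "the series" means these compounds.

Within the data shown here, compound 2 `CSc1c(SCC#CCO)cnc2ccccc12` gives 13.9 ug/mL in a functional assay on CCRF-CEM cells (Homo sapiens) for cytotoxicity, read by sulforhodamine B assay, with a stated time of 72 h (on this read-out higher numbers stand for weaker inhibition and lower numbers for stronger inhibition), the higher of the two numbers measured so far; its nearest neighbour is compound 1 `OCC#CCSc1cnc2ccccc2c1[Se]CC#CCBr`, which gives 0.2 ug/mL, and the step of a 70-fold higher number from compound 1 to compound 2 (1.84 log units; beyond the scatter) separates them. Compound 3 `C#CC[Se]c1c(SCC#CCO)cnc2ccccc12` alters compound 2 by a group of 4 heavy atoms (3 carbon, 1 selenium; no ring) in place of a group of 2 heavy atoms (1 carbon, 1 sulfur; no ring), on an aromatic carbon, putting a selenium-bearing group back on the same aromatic carbon that step had changed. That step is the only one that bears here, and it was large, so a clearly lower number is expected, estimated as the step of a 14-fold lower number from compound 2 to compound 3 (1.14 log units; beyond the scatter). Compound 3 is estimated at 1 ug/mL, between 0.2 ug/mL and 5 ug/mL.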

Compound 3, concentration for 50% inhibition: 1.9 ug/mL
Estimate against measurement, compound 3: 1.9-fold (0.28 log units) below; the measured number falls inside the stated range.
By their numbers in this assay, from the lowest: compound 1; then compound 3; then compound 2.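

Placing the selenium-bearing group on this aromatic carbon in place of methylsulfanyl brings a 7.3-fold lower number from compound 2 to compound 3 (0.86 log units; beyond the scatter) in this assay, so this position responds to the change even without bromine. The far end of the chain matters too: hydrogen in place of bromomethyl on the triple-bonded carbon gives a 9.5-fold higher number from compound 1 to compound 3 (0.98 log units; beyond the scatter) and accounts for part of the earlier gap. No measurement here explains either step. Still open, from the compounds shown here alone, is whether selenium itself matters, which a sulfur atom carrying the same chain would test, and how an amine or a longer chain at that end would compare.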